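Nitro on the phenyl of compound 2

A few compounds are considered here, and "the series" means these few. Any claim that something is new, unique, unknown or untested is made for them only; others in the source may bear on it.

For compound 1 (`OC[C@H]1O[C@H](Oc2ccc(-c3ccc(Cl)c(Cl)c3)cc2Cl)[C@@H](O)[C@@H](O)[C@@H]1O`) the entry in a physicochemical assay for lipophilicity, read by LC-MS, measured as octanol-water partition, with a stated time of 2 h, at pH 7.4, tested at 1 uM (on this read-out lower numbers stand for lower lipophilicity and higher numbers for higher lipophilicity), reads "not determined" (no result reported) and offers no comparison. Going by the values given here, compound 2 (`OC[C@H]1O[C@H](Oc2ccc(-c3ccccc3)cc2Cl)[C@@H](O)[C@@H](O)[C@@H]1O`) gives 2.6 in this assay and stands alone as the only number. Compound 3 (`O=[N+]([O-])c1cccc(-c2ccc(O[C@H]3O[C@H](CO)[C@@H](O)[C@H](O)[C@@H]3O)c(Cl)c2)c1`) differs from compound 2 by nitro in place of hydrogen on an aromatic carbon with nitro in place of hydrogen on an aromatic carbon, meta to a large group. Among the compounds with values here, no measured pair shows this change, so only a small downward step or none beyond the scatter is expected. The estimated a number 0.10 log units lower from compound 2 to compound 3 (within the scatter) in this assay remains an expectation. Compound 3 is estimated at 2.5 with an expected range from 2.1 to 2.9 as the working figures.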

Compound 3, distribution coefficient: 2.4
Estimate against measurement, compound 3: 0.10 log units above; measured number inside the range.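

Nitro in place of hydrogen on an aromatic carbon, meta to a large group, gives the first readable step in this series: in this assay the change is a number 0.20 log units lower from compound 2 to compound 3 (within the scatter). Phenyl to 3-nitrophenyl thus leaves the read-out within the usual scatter at this position. No measurement shown offers an explanation for this result.

On these data alone, whether other groups at this position, such as an amine or a carboxylic acid, would also stay within the scatter remains open. So does the outcome for nitro elsewhere on this ring.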